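Adding a Methyl to the Phenyl of Compound 1

The compounds below may be only part of what the source reports. "The series", "measured", "known", "first", "only" and "open" are said of these compounds alone.

In a physicochemical assay for lipophilicity, measured as octanol-water partition (a higher number here means a more lipophilic compound, a lower number a more polar compound), compound 1 `Cc1c(CN2CCCC2)cc(-c2ccccc2)n1Nc1ccnc2cc(Cl)ccc12` gives 4.6. Its fluoro counterpart, compound 2 `Cc1c(CN2CCCC2)cc(-c2ccc(F)cc2)n1Nc1ccnc2cc(Cl)ccc12`, gives 4.86, and its trifluoromethyl counterpart, compound 3 `Cc1c(CN2CCCC2)cc(-c2ccc(C(F)(F)F)cc2)n1Nc1ccnc2cc(Cl)ccc12`, gives 5.28. Compound 1 therefore cannot be told apart from compound 2, while it stands under compound 3.

Compound 4 `Cc1ccc(-c2cc(CN3CCCC3)c(C)n2Nc2ccnc3cc(Cl)ccc23)cc1` has not yet been measured. It differs from compound 1 by methyl in place of hydrogen on an aromatic carbon, the change from phenyl to 4-methylphenyl (methyl in place of hydrogen on an aromatic carbon).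

Among the compounds with values here, two measured steps bear most directly on this change, as each replaces the same hydrogen: a number 0.26 log units higher from compound 1 to compound 2 (within the scatter), and a number 0.68 log units higher from compound 1 to compound 3 (beyond the scatter). The step of a number 0.42 log units higher from compound 2 to compound 3 (beyond the scatter) shows that these two substituents also differ from each other. Within the data shown here, no methyl compound has been measured, so these steps serve only as a guide. An upward step of modest size, inside the span of those two steps, is expected in this assay. The estimated step is a number 0.45 log units higher from compound 1 to compound 4 (beyond the scatter). For compound 4 the expected value is 5.05, with an estimated range from 4.8 to 5.3.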

Compound 4, partition coefficient: 5.19
Beside the measured number, compound 4's estimate is 0.14 log units below it, within the range that was stated.
By their numbers in this assay, from the lowest: compounds 1 and 2 (each within the scatter of the next); then compounds 4 and 3 (each within the scatter of the next).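

In this assay, methyl on this aromatic carbon, para to a large group, gives a number 0.59 log units higher from compound 1 to compound 4 (beyond the scatter), so a single added carbon at this position is enough for a step beyond the scatter. Methyl can be separated from fluoro here, with a number 0.33 log units higher from compound 2 to compound 4 (beyond the scatter), but not from trifluoromethyl, with a number 0.09 log units lower from compound 3 to compound 4 (within the scatter), so these last two groups cannot be told apart at this place although their atoms differ. Nothing at hand gives a measured reason for the size of these steps.

As far as these compounds go, what an amine, a hydroxyl or a carboxylic acid would give at this same place stays open, as does whether an ethyl chain would stand apart from methyl. The compounds shown also leave open whether methyl gives a step of this size on any other carbon of the ring.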